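A few compounds are considered here, and "the series" means these few. Any claim that something is new, unique, unknown or untested is made for them only; others in the source may bear on it.

Among the measured compounds shown here, compound 1 `Cc1ccc(Nc2cc(C)nc(SCc3nc4ccccc4[nH]3)n2)cc1` is the only member of the set with a number in a functional assay on MGC-803 cells (Homo sapiens) for cytotoxicity, read by MTT assay, with a stated time of 72 h; a lower number here means a stronger inhibitor, a higher number a weaker inhibitor: compound 1 gives 7390 nM. Compound 2 `Cc1cc(N2CCNCC2)nc(SCc2nc3ccccc3[nH]2)n1` reaches only a limit in this assay, > 100000 nM. Compound 3 `Cc1cc(NCCO)nc(SCc2nc3ccccc3[nH]2)n1` likewise gives only a limit in this assay, > 100000 nM. Both steps away from compound 1 are large, an at least 13-fold higher number from compound 1 to compound 2 (1.13 log units; beyond the scatter) and an at least 13-fold higher number from compound 1 to compound 3 (1.13 log units; beyond the scatter), each ending at the limit of > 100000 nM in this assay, at which 2 of the 3 values shown sit. Compound 4 `Cc1cc(N2CCCCC2)nc(SCc2nc3ccccc3[nH]2)n1` carries the change (piperidin-1-yl in place of (4-methylphenyl)amino on an aromatic carbon). Of the measured steps, an at least 13-fold higher number from compound 1 to compound 2 (1.13 log units; beyond the scatter) bears most on it, a non-aromatic six-membered ring with one hetero atom again replacing (4-methylphenyl)amino. A large rise in this assay is therefore expected for compound 4, an 11-fold higher number from compound 1 to compound 4 (1.03 log units; beyond the scatter). Compound 4 is estimated at 80000 nM in this assay, with a range from 20000 nM to 300000 nM.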

Compound 4, half-maximal inhibitory concentration: > 100000 nM
Compound 4: only a limit was reported (the forecaster's own chance of this, stated with the estimate: 60%); middle value at least 1.2-fold (0.09 log units) from the limit.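

In this assay, piperidin-1-yl in place of (4-methylphenyl)amino gives an at least 13-fold higher number from compound 1 to compound 4 (1.13 log units; beyond the scatter), which extends the loss at this position to an entering group with 0 hydrogen-bond donors. Compound 4 gives > 100000 nM, a limit and not a number. The steps among compound 2, compound 3 and compound 4 cannot be read, and the three share one ceiling: the limit of > 100000 nM in this assay, at which 3 of the 4 values shown sit.

Only compound 1 keeps a number, so no order among the replacements can be drawn. From the compounds shown here alone, what (4-chlorophenyl)amino, (4-methoxyphenyl)amino or benzylamino would give at this position in this assay remains open.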